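A few compounds are considered here, and "the series" means these few. Any claim that something is new, unique, unknown or untested is made for them only; others in the source may bear on it.

Compound 1 `CN(C)CCCOc1ccc(CN2CC[C@H](NC(=O)c3ccc(C(F)(F)F)cc3)C2)cc1` carries a 4-(trifluoromethyl)phenyl group on the carbonyl carbon of its amide. In an assay on HEK293 cells for binding affinity to Urotensin-2 receptor (Homo sapiens), read by radioligand binding (on this read-out higher numbers stand for weaker inhibition and lower numbers for stronger inhibition), compound 1 gives < 10000 nM, which is a limit of the assay rather than a number. Compound 2 `CN(C)CCCOc1ccc(CN2CC[C@H](NC(=O)c3ccc(-c4ccccc4)cc3)C2)cc1`, with phenyl in place of trifluoromethyl, gives in this assay < 10000 nM, again a limit. Compound 3 `CN(C)CCCOc1ccc(CN2CC[C@H](NC(=O)c3ccco3)C2)cc1`, with furan-2-yl in place of the 4-(trifluoromethyl)phenyl, gives in this assay < 10000 nM, also a limit. Because all three values sit at the limit of < 10000 nM in this assay, at which 3 of the 3 values shown sit, the step that the two limits leave unreadable from compound 1 to compound 2 and the step that the two limits leave unreadable from compound 1 to compound 3 cannot be read in size or direction, and compound 1 cannot be placed relative to the other two. Compound 4 `CN(C)CCCOc1ccc(CN2CC[C@H](NC(=O)c3cc4ccccc4o3)C2)cc1` has not yet been measured in this assay. It differs from compound 1 in that (1-benzofuran-2-yl in place of 4-(trifluoromethyl)phenyl on a carbonyl carbon). Neither measured step gives a readable size, so the change from compound 1 to compound 4 has no direct precedent among the numbers shown. Compound 4 is therefore expected to fall near compound 1, with the step that the limit leaves unreadable from compound 1 to compound 4 estimated as one that cannot be separated from the scatter. The estimate for compound 4 in this assay is 1500 nM, within a range from 100 nM to 9000 nM.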

Compound 4, inhibition constant: 2510 nM
Compound 4: middle estimate off by 1.7-fold (0.22 log units), on the low side, and the stated range covers the measured number.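

No new step can be read for compound 4: its steps from compound 1 and from compound 3 stay unreadable in size and direction, because both of those compounds give only a limit of the assay: the limit of < 10000 nM in this assay, at which 3 of the 4 values shown sit.

The compounds shown leave open how 1-benzofuran-2-yl on the carbonyl carbon compares with 4-(trifluoromethyl)phenyl or furan-2-yl.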